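A fluoro for methyl swap on a shared core

The compounds below may be only part of what the source reports. "The series", "measured", "known", "first", "only" and "open" are said of these compounds alone.

Compound 1 `Cc1ccc(NC(=O)C(=O)NC(c2nc(C)c(CCO)s2)C2CCCCN2)c(F)c1` was examined in an ADME assay on TZM-b1 cells (Homo sapiens) for cytotoxicity, read by XTT assay, with a stated time of 3 days; a higher number here means that more compound is tolerated, a lower number that less compound is tolerated. In this assay compound 1 gives > 78800 nM, which is a limit of the assay rather than a measured number. Compound 2 `Cc1ccc(NC(=O)C(=O)NC(c2nc(C)c(CO)s2)C2CCCCN2)c(F)c1` gives > 88000 nM in this assay, also a limit. Compound 3 `CC(=O)c1ccc(NC(=O)C(=O)NC(c2nc(C)c(CO)s2)C2CCCCN2)cc1` gives > 86000 nM in this assay, again a limit. Compound 1 therefore stands only at a limit, and the two other values shown are limits as well, as the limit of > 78800 nM in this assay, at which 1 of the 3 values shown sits, the limit of > 86000 nM in this assay, at which 1 of the 3 values shown sits, and the limit of > 88000 nM in this assay, at which 1 of the 3 values shown sits, record. Two measured steps exist on this core: a step that the two limits leave unreadable from compound 1 to compound 2, a hydroxy in place of hydroxymethyl, and a step that the two limits leave unreadable from compound 2 to compound 3, a 4-acetylphenyl in place of 2-fluoro-4-methylphenyl; neither gives a readable size. Compound 4 `Cc1nc(C(NC(=O)C(=O)Nc2ccc(F)cc2F)C2CCCCN2)sc1CCO` differs from compound 1 by fluoro in place of methyl on an aromatic carbon, a change on the same outer ring that the second step also touched. Going by the values given here, no measured step sets a size for it, and all three values sit at limits, so no step beyond the scatter is expected in this assay. Compound 4 is expected to give about 80000 nM in this assay, within 30000 nM to 200000 nM. The expected step is a step that the limit leaves unreadable from compound 1 to compound 4, most likely ending at a limit once more.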

Compound 4, half-maximal cytotoxic concentration: > 84000 nM
Compound 4 was reported as a limit; the forecaster's own chance of this, stated with the estimate: 85%; middle value at least 1.0-fold (0.02 log units) away from the limit.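

Compound 1 and compound 4 are both recorded only as limits, so the step between them, fluoro in place of methyl, cannot be read. The compounds shown leave open at what concentration any of them harms the cells, and whether this swap changes that concentration at all.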